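The compounds below may be only part of what the source reports. "The series", "measured", "known", "first", "only" and "open" are said of these compounds alone.

Measured in a functional assay on A549 cells (Homo sapiens) for antiproliferative activity, read by MTT assay, with a stated time of 48 h; a higher number here means a weaker inhibitor, a lower number a stronger inhibitor:
compound 1, `COc1ccc2c(/C=C/C(=O)c3cc(OC)c(OC)c(SC)c3)c[nH]c2c1`: 115 nM
compound 2, `COc1ccc2c(/C=C/C(=O)c3cc(N)c(OC)c(OC)c3)c[nH]c2c1`: 193 nM
compound 3, `COc1cc(C(=O)/C=C/c2cn(C)c3ccccc23)cc(SC)c1OC`: 188 nM

Compound 1 and compound 2 share a core and differ by amino in place of methylsulfanyl on an aromatic carbon; the step is a 1.7-fold higher number from compound 1 to compound 2 (0.22 log units; within the scatter). Compound 3 has a different core; how the core of compound 1 and the core of compound 3 differ is not broken down here. Compound 4, `COc1cc(C(=O)/C=C/c2cn(C)c3ccccc23)cc(N)c1OC`, is not yet measured and differs from compound 3 by amino in place of methylsulfanyl on an aromatic carbon, the same change as from compound 1 to compound 2, at a place described in the same words. The expected step in this assay is a 1.7-fold higher number from compound 3 to compound 4 (0.23 log units; within the scatter), set beside the earlier one because it rests only on a 1.7-fold higher number from compound 1 to compound 2 (0.22 log units; within the scatter) and on the value of compound 3, 188 nM. Compound 4 is therefore estimated at 320 nM, with 150 nM to 700 nM as the expected range.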

Compound 4, half-maximal inhibitory concentration: 498 nM
The estimate for compound 4 lay 1.6-fold (0.19 log units) below the measured number, and the stated range covers the measured number.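

In this assay, amino in place of methylsulfanyl on an aromatic carbon gives a 2.6-fold higher number from compound 3 to compound 4 (0.42 log units; beyond the scatter). Set beside the step on the core of compound 1, this step does not differ from it: the same change on two cores in this assay, a 1.7-fold higher number (0.22 log units; within the scatter) from compound 1 to compound 2 and a 2.6-fold higher number (0.42 log units; beyond the scatter) from compound 3 to compound 4, 1.6-fold (0.20 log units) apart, within the scatter of two such steps. So, for these two cores, the change can be carried from one to the other as a working estimate, but the result rests on one pair per core and shows neither a rule for other cores in the series nor any reason for the size of either step.

Still open, as far as these compounds go, is how other groups at this place, such as hydroxy, dimethylamino or an acetamide, compare with amino and methylsulfanyl. From the compounds shown here alone, whether such groups would also carry from one core to the other remains open as well.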